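The source may report more compounds than this note shows. Statements on the series, on what has been measured and on what is new or still open speak of the compounds shown alone.

Working notes on the series.

Compound 1 `O=C1c2c[n+]([O-])c3ccccc3c2C(=O)c2c1c1ccccc1n2Cc1cn(CC(O)CO)nn1` and compound 2 `CC1(C)OC[C@H](Cn2cc(Cn3c4c(c5ccccc53)C(=O)c3c[n+]([O-])c5ccccc5c3C4=O)nn2)O1` share one core and differ only at the chain on the triazole nitrogen. In a functional assay on HCT-116 cells (Homo sapiens) for cytotoxicity, read by MTT assay, with a stated time of 72 h (on this read-out lower numbers stand for stronger inhibition and higher numbers for weaker inhibition), compound 1 gives 250 nM, and compound 2 gives 130 nM; the step of a 1.9-fold lower number from compound 1 to compound 2 (0.28 log units; within the scatter) is the only one measured so far. Compound 2 thus stands with the lower of the two numbers, but the gap to compound 1 is within the scatter, so no order between them can be claimed.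

Compound 3 `O=C1c2c[n+]([O-])c3ccccc3c2C(=O)c2c1c1ccccc1n2Cc1cn([C@@H]2O[C@H](CO)[C@@H](O)[C@H](O)[C@H]2O)nn1` takes the next step: 3,4,5-trihydroxy-6-(hydroxymethyl)oxan-2-yl in place of (2,2-dimethyl-1,3-dioxolan-4-yl)methyl on an aromatic nitrogen. For the measured compounds named here, the single measured step bears on it only loosely, since that step swapped two small groups on a saturated chain carbon and stayed within the scatter, whereas here the whole chain is replaced by a sugar ring bound straight to the aromatic nitrogen. Going by the values given here, the data give no step of this kind, so the expected change in this assay is a modest rise in the number, perhaps not beyond the scatter, with wide uncertainty.

Compound 3 is expected to give 300 nM in this assay, in the range 100 nM to 1000 nM; this estimate means a step of a 2.3-fold higher number from compound 2 to compound 3 (0.36 log units; beyond the scatter).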

Compound 3, half-maximal inhibitory concentration: 130 nM
Beside the measured number, compound 3's estimate is 2.3-fold (0.36 log units) above it, and the stated range covers the measured number.
By their numbers in this assay, from the lowest: compounds 2, 3 and 1 (each within the scatter of the next).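

In this assay, 3,4,5-trihydroxy-6-(hydroxymethyl)oxan-2-yl in place of (2,2-dimethyl-1,3-dioxolan-4-yl)methyl on an aromatic nitrogen gives no change at the digits printed from compound 2 to compound 3 (within the scatter), and the same group in place of 2,3-dihydroxypropyl gives a 1.9-fold lower number from compound 1 to compound 3 (0.28 log units; within the scatter). The earlier pair varied only the end of a chain, whereas these steps show that a six-membered non-aromatic ring with 1 hetero atom, bearing 4 hydrogen-bond donors and bound straight to that nitrogen, still leaves all three compounds within the scatter of one another. No measurement at hand gives a reason for this outcome. The compounds shown leave open whether a different kind of group on this nitrogen, such as a longer alkyl chain ending in an amine or a carboxylic acid, would move the number beyond the scatter. From the compounds shown here alone, whether the same reading holds in other cell lines also stays open.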